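This account rests on a few compounds, and the source may have more. Where it says the series, first, only, none or still open, it means among the compounds named here.

Compound 1, `N#CC1=C(NCN2CCCC2)N(c2ccccc2)C(=O)N2CCCCC(N3CCCC3)C12`, in a functional assay on the whole organism (strain albino) for inhibition, with Rattus norvegicus as the target, read by paw edema, with stated times of 1 h and 2 h, at a dose of 20 mmol/kg by the intraperitoneal route (on this read-out higher numbers stand for more inhibition at the one dose given (going by the name of the read-out) and lower numbers for less inhibition), gives 26.6%.
Compound 2, `N#CC1=C(NCC(=O)O)N(c2ccccc2)C(=O)N2CCCCC(N3CCCC3)C12`, in this assay gives 81.7%.
Compound 3, `N#Cc1c2n(c(=O)n(-c3ccccc3)c1=N)CCCCC2N1CCCC1`, in this assay gives 88.7%.

Among these three numbers compound 2 stands second highest. Its nearest neighbour is compound 3, whose value lies within the scatter of that of compound 2, so no order between the two can be read. Going by the values given here, compound 1 lies far lower, and the step of a number 55.1 percentage points higher from compound 1 to compound 2 (beyond the scatter) is the one change at this part of the molecule that has been measured.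

Compound 4, `CCOC(=O)C(=O)NC1=C(C#N)C2C(N3CCCC3)CCCCN2C(=O)N1c1ccccc1`, has not yet been measured in this assay. It differs from compound 2 in one place: (ethoxycarbonyl)carbonyl in place of carboxymethyl on an amine nitrogen. The measured step from compound 1 to compound 2 bears on this change only loosely, since it alters the same amine nitrogen substituent but in a different way. It shows that the group on this nitrogen can move the read-out by a large amount. Among the compounds with values here, the carboxymethyl group of compound 2 is exchanged for a group without a hydrogen-bond donor, and no measured compound carries such a group here, so the direction is uncertain; a moderate fall is held more likely than a rise. For compound 4 the estimated value is 60%, with a range from 35% to 85%, corresponding to the expected step of a number 21.7 percentage points lower from compound 2 to compound 4 (beyond the scatter).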

Compound 4, a percentage reported as inhibition, in the whole organism at one dose (the size of the read-out at that dose, not a potency): 83.6%
Compound 4: the middle estimate sits 23.6 percentage points below what was measured, and the stated range covers the measured number.
By their numbers in this assay, from the lowest: compound 1; then compounds 2, 4 and 3 (each within the scatter of the next).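

In this assay, the exchange of carboxymethyl for (ethoxycarbonyl)carbonyl on the amine nitrogen gives a number 1.9 percentage points higher from compound 2 to compound 4 (within the scatter), so a group with no hydrogen-bond donor can stand at this position with no readable loss of inhibition. The second new comparison, a number 57 percentage points higher from compound 1 to compound 4 (beyond the scatter), shows that two different groups on this nitrogen, carboxymethyl and (ethoxycarbonyl)carbonyl, both stand well clear of the (pyrrolidin-1-yl)methyl group of compound 1. No evidence is available to explain why these two groups give such similar results.

The compounds shown leave open whether a simple acetyl group or the ethyl ester of carboxymethyl would also keep this level of inhibition. They also leave open whether the low result belongs to the pyrrolidine amine specifically, or would also appear with a morpholine or a longer chain ending in an amine.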